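Swapping 4-hydroxycyclohexyl for cyclopropyl on an amide nitrogen

The source may hold more compounds than are shown below. What is called first, only, known or untested is meant among the compounds shown, and "the series" means these compounds.

Measured so far in a physicochemical assay for lipophilicity, at pH 7.4; a higher number here means a more lipophilic compound, a lower number a more polar compound
Compound 1 `CNC(=O)c1cc(C(=O)N[C@H]2[C@@H]3COC[C@@H]32)cc2c1OC[C@H]2c1ccccc1` gives 3.3
Compound 2 `CNC(=O)c1cc(C(=O)N[C@H]2CC[C@H](O)CC2)cc2c1OC[C@@]2(C)c1ccccc1` gives 3.3
Compound 3 `CNC(=O)c1cc(C(N)=O)cc2c1OC[C@H]2c1ccccc1` gives 2.7

Compound 2 sits at 3.3 and stands level with compound 1, the two sharing the highest of the three numbers. Compound 4 `CNC(=O)c1cc(C(=O)NC2CC2)cc2c1OC[C@@]2(C)c1ccccc1` has not yet been measured. The change from compound 2 is cyclopropyl in place of 4-hydroxycyclohexyl on an amide-type nitrogen and in words it puts cyclopropyl in place of 4-hydroxycyclohexyl on an amide-type nitrogen.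

For the measured compounds named here, one measured step touches the same kind of nitrogen, a number 0.60 log units lower from compound 1 to compound 3 (beyond the scatter) when a different group gives way to hydrogen. That modest step involves another group and another pair of compounds, so it offers a scale and not a direct precedent. Going by the values given here, no measured step shows this exact swap, so the upward direction expected here is a judgement. The estimated step is a number 0.30 log units higher from compound 2 to compound 4 (within the scatter) and it is of modest size. In this assay compound 4 is estimated at 3.6 within a range of 3.2 to 4 until it is measured.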

Compound 4, distribution coefficient: 4
Compound 4: middle estimate off by 0.40 log units, on the low side; low and high end bracket the measured number.
By their numbers in this assay, from the lowest: compound 3; then compounds 1 and 2 (each within the scatter of the next); then compound 4.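

In this assay, putting cyclopropyl in place of 4-hydroxycyclohexyl gives a number 0.70 log units higher from compound 2 to compound 4 (beyond the scatter). For the compounds shown here, this shows that the group on this amide-type nitrogen can move the number on the core of compound 2, whereas the only earlier step at such a nitrogen was a number 0.60 log units lower from compound 1 to compound 3 (beyond the scatter), on the core of compound 1. The swap changes several things at once, since the ring shrinks from six-membered to three-membered and the hydroxyl goes, and nothing available here explains the rise.

The compounds shown leave open how much of the step belongs to the ring and how much to the hydroxyl, which a plain cyclohexyl on the same nitrogen would help to separate. They also leave open whether the same swap gives a similar step on the core of compound 1.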